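The source may report more compounds than this note shows. Statements on the series, on what has been measured and on what is new or still open speak of the compounds shown alone.

Measured so far in a functional assay on MCF7 cells (Homo sapiens) for inhibition, read by MTT assay, with a stated time of 72 h; on this read-out lower numbers stand for stronger inhibition and higher numbers for weaker inhibition:
compound 1, `Nc1ccn(C[C@H](O)[C@H]2OC(=O)C(OCc3ccccc3)=C2OCc2ccccc2)c(=O)n1`, gives 7340 nM
compound 2, `NC1(CCn2cc(F)c(=O)[nH]c2=O)OC(=O)C(OCc2ccccc2)=C1OCc1ccccc1`, gives 20900 nM
compound 3, `NC1(CCn2ccc(=O)[nH]c2=O)OC(=O)C(OCc2ccccc2)=C1OCc1ccccc1`, gives > 100000 nM

For compound 3 the reading > 100000 nM is a limit of the assay, not a number; it sits at the limit of > 100000 nM in this assay, at which 1 of the 3 values shown sits. Compound 3 therefore stands weaker than compound 1 and compound 2 on the numbers shown, by an unknown margin.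

Compound 4, `Cc1cn(CCC2(N)OC(=O)C(OCc3ccccc3)=C2OCc2ccccc2)c(=O)[nH]c1=O`, differs from compound 3 by methyl in place of hydrogen on an aromatic carbon. Within the data shown here, the only measured step that bears on this carbon is an at least 4.7-fold higher number from compound 2 to compound 3 (0.67 log units; beyond the scatter), where loss of a single-atom group there weakened inhibition. Putting a single-atom group back is expected to move the number downward, but with a limit as starting point the size is uncertain.

Compound 4 is expected at 50000 nM, within 15000 nM to 200000 nM. The expected step is thus an at least 2.0-fold lower number from compound 3 to compound 4 (0.30 log units; that floor lies within the scatter).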

Compound 4, half-maximal inhibitory concentration: 80400 nM
For compound 4 the middle estimate is 1.6-fold (0.21 log units) below the measured one; low and high end bracket the measured number.
By their numbers in this assay, from the lowest: compound 1; then compound 2; then compound 4. At a limit, above all of these: compound 3.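

In this assay, compound 3 rests at a limit of the assay, not a number: the limit of > 100000 nM in this assay, at which 1 of the 4 values shown sits. Against that limit, methyl in place of hydrogen on this aromatic carbon gives an at least 1.2-fold lower number from compound 3 to compound 4 (0.09 log units; that floor lies within the scatter), so a gain from methyl is not established. Methyl does not stand in for fluoro at this position, with a 3.8-fold higher number from compound 2 to compound 4 (0.59 log units; beyond the scatter), so the identity of the group matters here and fluoro gives the lower number of the two.

From the compounds shown here alone, how chloro, an amine or an ethyl chain on this carbon would read against compound 2 stays open. Going by these compounds, the true size of the step from hydrogen to methyl also stays open.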